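The source may report more compounds than this note shows. Statements on the series, on what has been measured and on what is new or still open speak of the compounds shown alone.

In a functional assay on RPMI-8226 cells (Homo sapiens) for antiproliferative activity, read by radiometric assay, with a stated time of 72 h (a higher number here means a weaker inhibitor, a lower number a stronger inhibitor), compound 1 `Cc1ccccc1Nc1ncnc2cc(NC(=O)CCCCCCC(=O)NO)sc12` gives 1750 nM as its measured value. Two relatives sharing that core have also been measured: compound 2 `O=C(CCCCCCC(=O)Nc1cc2ncnc(Nc3ccc(Cl)cc3F)c2s1)NO` with 1900 nM and compound 3 `Cc1ccc(F)c(Nc2ncnc3cc(NC(=O)CCCCCCC(=O)NO)sc23)c1` with 1060 nM as their values. Compound 1 cannot be ranked against either of them, since its steps to both lie within the scatter.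

Compound 4 `CCc1ccc(Nc2ncnc3cc(NC(=O)CCCCCCC(=O)NO)sc23)cc1` has not yet been measured. The change from compound 1 is 4-ethylphenyl in place of 2-methylphenyl on a nitrogen on an aromatic ring and amounts to 4-ethylphenyl in place of 2-methylphenyl on a nitrogen on an aromatic ring.

Three measured steps exchanged the group at that same place. They are a 1.1-fold higher number from compound 1 to compound 2 (0.04 log units; within the scatter) and a 1.7-fold lower number from compound 1 to compound 3 (0.22 log units; within the scatter) and a 1.8-fold lower number from compound 2 to compound 3 (0.25 log units; within the scatter) and all three lie within the scatter. Among the compounds with values here, the 4-ethylphenyl group appears in none of the measured compounds, so this exact change is untested, and three compounds are a thin basis for any pattern. Even so, the measured steps give no reason to expect a shift beyond the scatter in this assay, and no direction can be favoured. The expected step is a 1.2-fold lower number from compound 1 to compound 4 (0.07 log units; within the scatter) and would be too small to read as a real change. Compound 4 is estimated at 1500 nM with an expected range from 700 nM to 3200 nM in this measurement.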

Compound 4, half-maximal inhibitory concentration: 2540 nM
For compound 4 the middle estimate is 1.7-fold (0.23 log units) below the measured one, within the range that was stated.
By their numbers in this assay, from the lowest: compounds 3, 1, 2 and 4 (each within the scatter of the next, the first and the last beyond it).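

In this assay, the 4-ethylphenyl group gives a 1.5-fold higher number from compound 1 to compound 4 (0.16 log units; within the scatter) and a 1.3-fold higher number from compound 2 to compound 4 (0.13 log units; within the scatter), so compound 4 cannot be told apart from either of these relatives. Within the data shown here, the new information lies in a 2.4-fold higher number from compound 3 to compound 4 (0.38 log units; beyond the scatter), the first step at this position to pass beyond the scatter, though only modestly: the group on the nitrogen can move the number after all, at least between these two compounds, while compound 1 and compound 2 remain within the scatter of both. The measurements shown offer nothing that would explain this gap.

The step from compound 3 to compound 4 exchanges one whole group for another, so it cannot show which part of either group matters, and a 4-methylphenyl or 2-ethylphenyl group would be needed to separate the length of the chain from its place on the ring. As far as these compounds go, it also remains open whether an amine or a carboxylic acid on the phenyl ring, or a propyl or longer chain in place of the ethyl, would carry the number further in either direction.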